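The source may hold more compounds than are shown below. What is called first, only, known or untested is meant among the compounds shown, and "the series" means these compounds.

Of the compounds shown here, two have been measured in a functional assay on CHO cells for agonist activity at Free fatty acid receptor 1 (Rattus norvegicus), read by calcium flux; on this read-out higher numbers stand for an effect only at larger amounts of compound and lower numbers for an effect already at smaller amounts. Compound 1 `Cc1cccc(C)c1-c1cccc(COc2ccc(CCC(=O)O)nc2)c1` gives 210 nM. Compound 2 `Cc1cccc(C)c1-c1cccc(COc2ccc(CC(F)C(=O)O)cn2)c1` gives 250 nM, the higher of the two numbers, though its gap to compound 1 lies within the usual scatter, so the two cannot be told apart on these numbers. Compound 3 `COC(Cc1ccc(OCc2cccc(-c3c(C)cccc3C)c2)nc1)C(=O)O` has not yet been measured. It differs from compound 2 in one place: methoxy in place of fluoro on a saturated chain carbon bound to a carbonyl carbon and a saturated chain carbon. For the measured compounds named here, no change of this kind has been measured within this set, so there is no earlier step to lean on. Since the change is confined to a single position on the chain, no movement beyond the scatter is expected, and the expected step in this assay is no change at the digits printed from compound 2 to compound 3 (within the scatter). Compound 3 is therefore estimated to give about 250 nM, with a plausible range from 80 nM to 800 nM.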

Compound 3, half-maximal effective concentration: > 10000 nM
Compound 3: a limit, no number; the forecaster's own chance of this, stated with the estimate: 5%; middle value at least 40-fold (1.60 log units) away from the limit.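

Putting methoxy in place of fluoro on the saturated chain carbon bound to a carbonyl carbon and a saturated chain carbon is far from a neutral swap: in this assay it gives an at least 40-fold higher number from compound 2 to compound 3 (1.60 log units; beyond the scatter). Compound 3 carries a limit of the assay and not a number: the limit of > 10000 nM in this assay, at which 1 of the 3 values shown sits. The earlier compounds shown here gave no sign of this, and the pair now shows that a change at this single chain position, with one heavy atom leaving and two entering, can be enough to take the read-out from a measurable number to that limit.

The compounds shown leave open whether the oxygen of the methoxy or simply the larger group accounts for the step. A hydroxy or a methyl on this same carbon would help separate those two readings.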